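A few compounds are considered here, and "the series" means these few. Any claim that something is new, unique, unknown or untested is made for them only; others in the source may bear on it.

Measured so far in an assay on isolated protein for inhibition of protein kinase C theta type (Homo sapiens), read by TR-FRET, with a stated time of 2 h; on this read-out lower numbers stand for stronger inhibition and higher numbers for weaker inhibition:
- compound 1 `N#Cc1cnc(NCc2cnccc2C(F)(F)F)cc1NC[C@H]1C[C@@H](O)C1`: 300 nM
- compound 2 `N#Cc1cnc(NCc2cnccc2C(F)(F)F)cc1NC[C@H]1C[C@H](O)C1`: 700 nM
- compound 3 `N#Cc1cnc(NCc2cnccc2C(F)(F)F)cc1N[C@H]1CC[C@@H](O)CC1`: 100 nM

Compound 3 holds the lowest number of the three in this assay. The steps to it are a 3.0-fold lower number from compound 1 to compound 3 (0.48 log units; beyond the scatter) and a 7.0-fold lower number from compound 2 to compound 3 (0.85 log units; beyond the scatter), both beyond the scatter. Between the two cyclobutyl compounds the step is a 2.3-fold higher number from compound 1 to compound 2 (0.37 log units; beyond the scatter), which rests on (the fact that compounds 1 and 2 differ only in the configuration as drawn).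

Compound 4 `N#Cc1cnc(NCc2cnccc2C(F)(F)F)cc1N[C@H]1CC[C@@H](n2cncn2)CC1` keeps the shared core and the 4-substituted cyclohexyl of compound 3; the change is 1H-1,2,4-triazol-1-yl in place of hydroxy on a saturated ring carbon. Going by the values given here, none of the measured steps touches this position: the steps seen so far concern the ring and its linker on the nitrogen of the core, and the configuration of the cyclobutyl pair. Among the compounds with values here, no precedent for exchanging the hydroxy against an aromatic five-membered ring with three hetero atoms exists within these three compounds, so the direction is open. The expectation is a step within or only modestly beyond the scatter, a 2.0-fold higher number from compound 3 to compound 4 (0.30 log units; within the scatter). Compound 4 is therefore estimated at 200 nM, with a range from 50 nM to 800 nM.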

Compound 4, half-maximal inhibitory concentration: 100 nM
Estimate against measurement, compound 4: 2.0-fold (0.30 log units) above, within the range that was stated.
By their numbers in this assay, from the lowest: compounds 3 and 4 (each within the scatter of the next); then compound 1; then compound 2.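

In this assay, going by these compounds alone, the exchange of hydroxy for 1H-1,2,4-triazol-1-yl on the saturated ring carbon gives no change at the digits printed from compound 3 to compound 4 (within the scatter) and is the first reading at this position. In this pair, a group of 5 heavy atoms with 0 hydrogen-bond donors replaces one of 1 heavy atom with 1 hydrogen-bond donor, and the number holds, so this position accepts the larger aromatic ring without a measurable step. Nothing measured here gives a cause for this step.

Open, on these data alone, is whether the number also holds at this position with an amine, a carboxylic acid or a longer chain. Also open, as far as these compounds go, is whether 1H-1,2,4-triazol-1-yl in place of hydroxy on the cyclobutyl ring of compound 1 would behave the same way in this assay as well.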